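Notes on the step from compound 1 to compound 3

The compounds below may be only part of what the source reports. "The series", "measured", "known", "first", "only" and "open" are said of these compounds alone.

compound 1 `COc1ccc([C@H](C)NC(=O)/C(C#N)=C/c2cccc(Br)n2)cc1` | 1400 nM
compound 2 `COC(=O)C[C@H](NC(=O)/C(C#N)=C/c1cccc(Br)n1)c1ccccc1` | 3300 nM

Among the measured compounds shown here, in a functional assay on U-266 cells (Homo sapiens) for antiproliferative activity, read by MTT assay, with a stated time of 72 h (a higher number here means a weaker inhibitor, a lower number a stronger inhibitor), compound 1 gives 1400 nM and holds the lower of only two numbers. Compound 2 reads higher at 3300 nM and the gap between them lies beyond the usual scatter.

The next compound to be tested is compound 3 `C[C@H](NC(=O)/C(C#N)=C/c1cccc(Br)n1)c1ccccc1F` with 2-fluorophenyl in place of 4-methoxyphenyl on a saturated chain carbon bound to an amide-type nitrogen and a saturated chain carbon (the counted difference: 2-fluorophenyl in place of 4-methoxyphenyl on a saturated chain carbon bound to an amide-type nitrogen and a saturated chain carbon). For the measured compounds named here, no measured pair isolates this change, so the data offer no direct guide to its size. Going by the values given here, with so little to go on, the expectation stays close to the start of the step and leans toward a higher number, in the direction of compound 2 at 3300 nM as the only other reading. The expected change is a 1.4-fold higher number from compound 1 to compound 3 (0.15 log units; within the scatter) and no step beyond the scatter is expected. Compound 3 is estimated at 2000 nM (expected range 600 nM to 6500 nM).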

Compound 3, half-maximal inhibitory concentration: 2000 nM
The estimate for compound 3 equals the measured number at the digits printed; low and high end bracket the measured number.
By their numbers in this assay, from the lowest: compounds 1, 3 and 2 (each within the scatter of the next, the first and the last beyond it).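

In this assay, among the compounds shown here, the replacement of 4-methoxyphenyl by 2-fluorophenyl on a saturated chain carbon bound to an amide-type nitrogen and a saturated chain carbon gives a 1.4-fold higher number from compound 1 to compound 3 (0.15 log units; within the scatter) and provides the first measured pair that differs in one place. This position therefore accepts either of these two substituted phenyl groups without a step beyond the scatter, although 2-fluorophenyl has one heavy atom fewer and no hydrogen-bond acceptor, so for this pair the acceptor counted on 4-methoxyphenyl is not required to keep the number within the scatter. No measurement at hand bears on why the two readings lie so close.

Still open, from the compounds shown here alone, is how this carbon responds to a group of a different kind, such as an amine, a carboxylic acid or a longer chain in place of the aromatic ring. A single pair also sets no trend across substituted phenyl groups, so nothing here shows whether the tolerance seen with these two groups extends to others at this position.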